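Adding a second methyl to the benzamide nitrogen

This account rests on a few compounds, and the source may have more. Where it says the series, first, only, none or still open, it means among the compounds named here.

Of the compounds shown here, three sharing one core have been measured in an ADME assay on a cell-free system (plasma, Homo sapiens) for protein binding, with Plasma (Rattus norvegicus) as the target, with a stated time of 1 h; a lower number here means a smaller unbound share, a higher number a larger unbound share of the compound. Compound 1 `CNC(=O)c1cc(F)ccc1CNC(=O)c1nc(C(C)(C)C)n(C)c(=O)c1O` gives 0.07 and stands highest of the three, though compound 2 `Cn1c(C(C)(C)C)nc(C(=O)NCc2ccc(F)cc2C(N)=O)c(O)c1=O` with 0.06 sits within the scatter of it, a 1.2-fold lower number from compound 1 to compound 2 (0.07 log units; within the scatter). Compound 3 `CC(C)NC(=O)c1cc(F)ccc1CNC(=O)c1nc(C(C)(C)C)n(C)c(=O)c1O` gives 0.01, and a 7.0-fold lower number from compound 1 to compound 3 (0.85 log units; beyond the scatter), while a 6.0-fold lower number from compound 2 to compound 3 (0.78 log units; beyond the scatter). Compound 4 `CN(C)C(=O)c1cc(F)ccc1CNC(=O)c1nc(C(C)(C)C)n(C)c(=O)c1O` differs from compound 1 by methyl in place of hydrogen on an amide-type nitrogen, taking methylcarbamoyl to dimethylcarbamoyl. The step from compound 1 to compound 3 bears on this, as it also enlarges the group on that nitrogen, but the present change enters a single carbon, so a smaller lowering in this assay is expected. Compound 4 is therefore estimated at 0.035, between 0.015 and 0.07, a step of a 2.0-fold lower number from compound 1 to compound 4 (0.30 log units; within the scatter).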

Compound 4, unbound fraction: 0.18
Beside the measured number, compound 4's estimate is 5.1-fold (0.71 log units) below it; the measured number lies above the stated range.
By their numbers in this assay, from the lowest: compound 3; then compounds 2 and 1 (each within the scatter of the next); then compound 4.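

On the amide-type nitrogen, a second methyl raises the number in this assay, with a 2.6-fold higher number from compound 1 to compound 4 (0.41 log units; beyond the scatter), so enlarging the group there does not always lower it, as the isopropyl of compound 3 did. Dimethylamino on the carbonyl carbon also stands clear of the other two groups, with a 3.0-fold higher number from compound 2 to compound 4 (0.48 log units; beyond the scatter) and an 18-fold higher number from compound 3 to compound 4 (1.26 log units; beyond the scatter). Nothing measured here accounts for this rise.

The compounds shown leave open whether the rise extends to a larger pair of substituents on that nitrogen, such as diethylamino, or to a pyrrolidine ring.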